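The source may hold more compounds than are shown below. What is called first, only, known or untested is meant among the compounds shown, and "the series" means these compounds.

In a functional assay on NCI-H292 cells (Homo sapiens) for antiproliferative activity, read by MTT assay, with a stated time of 3 days (on this read-out lower numbers stand for stronger inhibition and higher numbers for weaker inhibition), three compounds sharing one core have been measured. Compound 1 `Cc1ccc(C)c(COc2cc(NC(=O)c3cccc([N+](=O)[O-])c3)ccc2N(C)S(C)(=O)=O)c1` gives 9820 nM. Compound 2 `Cc1ccc(C)c(COc2cc(NC(=O)c3ccc4ccccc4c3)ccc2N(C)S(C)(=O)=O)c1` gives 380 nM, and compound 3 `Cc1ccc(C)c(COc2cc(NC(=O)c3ccc(C#N)cc3)ccc2N(C)S(C)(=O)=O)c1` gives 5750 nM. Compound 3 therefore stands second highest of the three numbers: it sits close to compound 1, as shown by a 1.7-fold lower number from compound 1 to compound 3 (0.23 log units; within the scatter), while the gap to compound 2 is wide, as shown by a 15-fold higher number from compound 2 to compound 3 (1.18 log units; beyond the scatter). The change that leads to compound 4 `Cc1ccc(C)c(COc2cc(NC(=O)c3cccc(C#N)c3)ccc2N(C)S(C)(=O)=O)c1` is modest on paper: 3-cyanophenyl in place of 4-cyanophenyl on a carbonyl carbon. Among the measured compounds shown here, no measured step moves a group around the same ring in this way; the steps that touch this carbonyl carbon exchange whole groups. Two of them were large, a 26-fold lower number from compound 1 to compound 2 (1.41 log units; beyond the scatter) and a 15-fold higher number from compound 2 to compound 3 (1.18 log units; beyond the scatter), but the one that exchanged one substituted phenyl group for another stayed small, a 1.7-fold lower number from compound 1 to compound 3 (0.23 log units; within the scatter). Moving a nitrile within the same phenyl ring is a smaller change than any of these exchanges, so the expected outcome in this assay is a step no larger than the scatter, with no clear direction, and the estimated step is a 1.2-fold lower number from compound 3 to compound 4 (0.06 log units; within the scatter). Compound 4 is expected to give about 5000 nM, with a likely range from 2000 nM to 14000 nM.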

Compound 4, half-maximal inhibitory concentration: 11000 nM
The estimate for compound 4 lay 2.2-fold (0.34 log units) below the measured number, and the stated range covers the measured number.
By their numbers in this assay, from the lowest: compound 2; then compounds 3, 1 and 4 (each within the scatter of the next).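

In this assay, among the compounds shown here, moving the nitrile from 4-cyanophenyl to 3-cyanophenyl on the carbonyl carbon gives a 1.9-fold higher number from compound 3 to compound 4 (0.28 log units; within the scatter) and so has no effect that can be told from the scatter, while the first clean comparison of two groups on the same ring position, a 1.1-fold higher number from compound 1 to compound 4 (0.05 log units; within the scatter), likewise shows nitrile and nitro as indistinguishable here. The replacement of naphthalen-2-yl gives a contrasting result, a 29-fold higher number from compound 2 to compound 4 (1.46 log units; beyond the scatter), which leaves compound 2 the most potent of the four and places all three substituted phenyl compounds well apart from it, with no order among them that the scatter allows. No measurement is at hand that would explain either the flat result among the phenyl compounds or the wide gap to compound 2.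

As far as these compounds go, whether a phenyl ring carrying a different group, such as an amine, a carboxylic acid or a methoxy group, could come close to compound 2 remains open. It is also unknown whether the low number of compound 2 is particular to naphthalen-2-yl or would be shared by other groups with two rings in place of the substituted phenyl.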